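This account rests on a few compounds, and the source may have more. Where it says the series, first, only, none or still open, it means among the compounds named here.

Series notes. In a functional assay on SMMC-7721 cells (Homo sapiens) for antiproliferative activity, read by MTT assay, with a stated time of 72 h (a higher number here means a weaker inhibitor, a lower number a stronger inhibitor), compound 2 `C#CCSc1nc(Sc2nccs2)c(C#N)c(-c2ccc(Br)cc2)n1` gives 3990 nM, the second highest of three numbers, though within the scatter of both neighbours: compound 1 `C#CCSc1nc(Sc2nccs2)c(C#N)c(-c2ccc(C)cc2)n1` gives 2450 nM and compound 3 `C#CCSc1nc(Sc2nnnn2CCN(C)C)c(C#N)c(-c2ccc(Cl)cc2)n1` gives 7340 nM. For the measured compounds named here, the only single-point step, a 1.6-fold higher number from compound 1 to compound 2 (0.21 log units; within the scatter), is within the scatter. Compound 4 `C#CCSc1nc(Sc2nccs2)c(C#N)c(-c2ccc[nH]2)n1` differs from compound 2 in one place: 1H-pyrrol-2-yl in place of 4-bromophenyl on an aromatic carbon. Going by the values given here, no measured step replaces the whole aromatic ring at this place, so the bromo-for-methyl step is the only guide, and it was flat. The expected step of a 1.1-fold higher number from compound 2 to compound 4 (0.05 log units; within the scatter) is therefore none beyond the scatter, with the wider range reflecting the untested ring swap. Compound 4 is expected at 4500 nM, between 1500 nM and 14000 nM.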

Compound 4, half-maximal inhibitory concentration: > 20000 nM
Compound 4: only a limit was reported; the forecaster's own chance of this, stated with the estimate: 5%; at least 4.4-fold (0.64 log units) between middle value and limit.
By their numbers in this assay, from the lowest: compounds 1, 2 and 3 (each within the scatter of the next, the first and the last beyond it). At a limit, above all of these: compound 4.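

In this assay, this aromatic carbon proves sensitive to the ring it carries: 1H-pyrrol-2-yl gives an at least 5.0-fold higher number from compound 2 to compound 4 (0.70 log units; beyond the scatter) in place of 4-bromophenyl and an at least 8.1-fold higher number from compound 1 to compound 4 (0.91 log units; beyond the scatter) in place of 4-methylphenyl. The earlier change at the end of the phenyl ring, a 1.6-fold higher number from compound 1 to compound 2 (0.21 log units; within the scatter), stayed within the scatter and gave no sign of this. Compound 4 is reported only as a limit: the limit of > 20000 nM in this assay, at which 1 of the 4 values shown sits.

Going by these compounds, the full size of both steps therefore stays open. Also open, on these data alone, is whether the five-membered ring or its hydrogen-bond donor accounts for the change, which 1-methylpyrrol-2-yl or thiophen-2-yl at this place could separate.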